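Replacing the aromatic ring on the saturated chain carbon

A few compounds are considered here, and "the series" means these few. Any claim that something is new, unique, unknown or untested is made for them only; others in the source may bear on it.

Measured so far:
compound 1 `Clc1ccc(CO/N=C/c2c(-c3ccc4ccccc4c3)nc3occn23)cc1Cl` — 370 nM
compound 2 `FC(F)(F)c1ccc(CO/N=C/c2c(-c3ccc4ccccc4c3)nc3occn23)cc1` — 470 nM

In an assay on HepG2 cells for agonist activity at nuclear receptor subfamily 1 group I member 3 (Homo sapiens), read by a luciferase reporter, with a stated time of 23 h (on this read-out lower numbers stand for an effect already at smaller amounts and higher numbers for an effect only at larger amounts of compound), compound 1 gives 370 nM, and in the same assay compound 2 gives 470 nM. Compound 2 thus holds the highest of the two numbers, yet the step of a 1.3-fold higher number from compound 1 to compound 2 (0.10 log units; within the scatter) lies within the scatter, so the two compounds cannot be told apart on these data.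

Compound 3 `Fc1c(F)c(F)c(CO/N=C/c2c(-c3ccc4ccccc4c3)nc3occn23)c(F)c1F` arises from compound 2 through a single change: 2,3,4,5,6-pentafluorophenyl in place of 4-(trifluoromethyl)phenyl on a saturated chain carbon bound to an oxygen on an unsaturated carbon. Among the compounds with values here, only one measured step bears on a swap of the aromatic ring at this position, the step of a 1.3-fold higher number from compound 1 to compound 2 (0.10 log units; within the scatter), and it was within the scatter. With nothing else to go on, no step beyond the scatter in this assay is expected here, in either direction.

Compound 3 is therefore expected to give about 500 nM in this assay, with a range from 200 nM to 1300 nM. That estimate corresponds to an expected step of a 1.1-fold higher number from compound 2 to compound 3 (0.03 log units; within the scatter).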

Compound 3, half-maximal effective concentration: 1700 nM
Beside the measured number, compound 3's estimate is 3.4-fold (0.53 log units) below it; measured number outside the range, above it.
By their numbers in this assay, from the lowest: compounds 1 and 2 (each within the scatter of the next); then compound 3.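

In this assay, the aromatic ring on the saturated chain carbon proves able to move the number beyond the scatter, which the swap of 4-(trifluoromethyl)phenyl for 3,4-dichlorophenyl did not show. Putting 2,3,4,5,6-pentafluorophenyl at this place gives a 3.6-fold higher number from compound 2 to compound 3 (0.56 log units; beyond the scatter) and likewise a 4.6-fold higher number from compound 1 to compound 3 (0.66 log units; beyond the scatter), so this ring stands apart from the other two, which cannot be told apart from each other. Nothing measured here accounts for this step.

With only three rings shown, it remains open whether the step follows the count of fluorine atoms on the ring or belongs to this one ring alone. Also open, going by these compounds, is how the number would respond to a ring bearing an amine or a carboxylic acid, or to a longer chain in place of the saturated chain carbon.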